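Acylguanidine series: aryl amine in place of cyclopentyloxy

A few compounds are considered here, and "the series" means these few. Any claim that something is new, unique, unknown or untested is made for them only; others in the source may bear on it.

Measured so far:
compound 1, `Cc1cc(-c2ccco2)c(S(C)(=O)=O)cc1C(=O)N=C(N)N`, 16 nM
compound 2, `Cc1cc(OC2CCCC2)c(S(C)(=O)=O)cc1C(=O)N=C(N)N`, 27 nM

Within the data shown here, in a functional assay for inhibition of sodium/hydrogen exchanger (Oryctolagus cuniculus) (a higher number here means a weaker inhibitor, a lower number a stronger inhibitor), compound 2 stands at the higher of the two numbers, with compound 1 its only neighbour; the step of a 1.7-fold higher number from compound 1 to compound 2 (0.23 log units; within the scatter), cyclopentyloxy in place of furan-2-yl on an aromatic carbon, stays within the scatter. Compound 3, `Cc1cc(Nc2cccc(Cl)c2)c(S(C)(=O)=O)cc1C(=O)N=C(N)N`, differs from compound 2 by (3-chlorophenyl)amino in place of cyclopentyloxy on an aromatic carbon.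

Among the measured compounds shown here, only the step from compound 1 to compound 2 bears on this change, and it shows that swapping the group on this aromatic carbon, between a five-membered aromatic ring and a cyclopentyloxy, moved this assay by no more than the scatter. For the measured compounds named here, no measured compound carries an amine-linked aryl group, so the comparison is loose. A small step is therefore expected, if anything toward a lower number, as a 1.4-fold lower number from compound 2 to compound 3 (0.13 log units; within the scatter). Compound 3 is estimated at 20 nM, with a range of 7 nM to 60 nM.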

Compound 3, half-maximal inhibitory concentration: 33 nM
The estimate for compound 3 lay 1.7-fold (0.22 log units) below the measured number; the range from low to high includes it.
By their numbers in this assay, from the lowest: compounds 1, 2 and 3 (each within the scatter of the next, the first and the last beyond it).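

In this assay, (3-chlorophenyl)amino on this aromatic carbon, ortho to the methylsulfonyl group, cannot be told apart from cyclopentyloxy, with a 1.2-fold higher number from compound 2 to compound 3 (0.09 log units; within the scatter) as the step. Against furan-2-yl, the same group gives a 2.1-fold higher number from compound 1 to compound 3 (0.31 log units; beyond the scatter), the first step at this position to pass the scatter, and a modest one, so an amine-linked aryl group is accommodated here with little loss relative to the furan-2-yl compound. No available evidence accounts for either step.

From the compounds shown here alone, the separate contributions of the amine link and the 3-chlorophenyl ring remain open: phenylamino, 3-chlorophenoxy and a simple alkylamine such as cyclopentylamino would each divide the change differently. The effect of moving the chlorine around the ring, or of replacing it with methoxy or a carboxylic acid, is also unresolved.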